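The source may report more compounds than this note shows. Statements on the series, on what has been measured and on what is new or still open speak of the compounds shown alone.

Measured compounds:
Compound 1 `O=[N+]([O-])c1ccc(-c2nc3cc(C(F)(F)F)ccc3[nH]2)cc1` gives 18000 nM in an ADME assay on BHK cells (Mesocricetus auratus) for cytotoxicity, read by MTT assay, with a stated time of 96 h; on this read-out higher numbers stand for lower toxicity in this test and lower numbers for higher toxicity in this test.
Compound 2 `CC(=O)Nc1ccc(-c2nc3cc(C(F)(F)F)ccc3n2C2CCCCC2)cc1` gives 15000 nM in this assay.
Compound 3 `CC(=O)Nc1ccc(-c2nc3cc(C(F)(F)F)ccc3[nH]2)cc1` gives 53000 nM in this assay.

Compound 4 `O=[N+]([O-])c1ccc(-c2nc3cc(C(F)(F)F)ccc3n2C2CCCCC2)cc1` has not yet been measured in this assay. It differs from compound 2 by a single change, (nitro in place of acetamido on an aromatic carbon). The same change has already been measured once, from compound 3 to compound 1, where it is described as nitro in place of acetamido on an aromatic carbon and gave a 2.9-fold lower number from compound 3 to compound 1 (0.47 log units; beyond the scatter). The two place descriptions agree word for word, so the change is the same in both pairs. The cores on which it is made differ by cyclohexyl in place of hydrogen on an aromatic nitrogen, and that difference gave a 3.5-fold higher number from compound 2 to compound 3 (0.55 log units; beyond the scatter). Compound 1 and compound 2 lie within the scatter of each other.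

For compound 4 the expected step in this assay is a 2.7-fold lower number from compound 2 to compound 4 (0.44 log units; beyond the scatter), beside the earlier one, resting on a 2.9-fold lower number from compound 3 to compound 1 (0.47 log units; beyond the scatter) carrying over to compound 2, which gave 15000 nM. Compound 4 is therefore estimated at 5500 nM, with a likely range from 2500 nM to 13000 nM.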

Compound 4, half-maximal cytotoxic concentration: > 100000 nM
Compound 4 ended at the assay's limit; the forecaster's own chance of this, stated with the estimate: 5%; middle value at least 18-fold (1.25 log units) away from the limit.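

In this assay compound 4 gives > 100000 nM, which is a limit of the assay and not a number. On the cores bearing cyclohexyl, nitro in place of acetamido gives an at least 6.6-fold higher number from compound 2 to compound 4 (0.82 log units; beyond the scatter), which runs opposite to the step on the cores bearing hydrogen on the aromatic nitrogen, so the change did not carry from one core to the other: the same change on two cores in this assay, a 2.9-fold lower number (0.47 log units; beyond the scatter) from compound 3 to compound 1 and an at least 6.6-fold higher number (0.82 log units; beyond the scatter) from compound 2 to compound 4, at least 19-fold (1.29 log units) apart, beyond the scatter of two such steps Cyclohexyl in place of hydrogen likewise gives an at least 5.5-fold higher number from compound 1 to compound 4 (0.74 log units; beyond the scatter) among the nitro compounds, against the opposite direction among the acetamido compounds, but with one pair on each side and a limit at one corner, this shows only that the two changes do not add up here, not how large the true gap is or what lies behind it: the same change on two cores in this assay, a 3.5-fold higher number (0.55 log units; beyond the scatter) from compound 2 to compound 3 and an at least 5.5-fold lower number (0.74 log units; beyond the scatter) from compound 4 to compound 1, at least 19-fold (1.29 log units) apart, beyond the scatter of two such steps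

On these data alone, it remains open whether the reversal would also appear with an amine or a carboxylic acid in place of nitro. The same question stands for a methyl group or a longer chain in place of cyclohexyl on the aromatic nitrogen.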